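Swapping the Amide Cap: Distribution Expected to Hold

The source may report more compounds than this note shows. Statements on the series, on what has been measured and on what is new or still open speak of the compounds shown alone.

Measured so far:
- Compound 1 `CCn1c(-c2cnc(C)nc2)nc2c(O[C@H]3CCN(C(=O)C4CC4)C3)ncnc21`: 0.7 L/kg
- Compound 2 `CCC(=O)N1CC[C@H](Oc2ncnc3c2nc(-c2cnc(C)nc2)n3CC)C1`: 2.7 L/kg
- Compound 3 `CCn1c(-c2ccc(C(F)(F)F)nc2)nc2c(O[C@H]3CCN(C(=O)c4cocn4)C3)ncnc21`: 3.4 L/kg

Of the compounds shown here, three sharing one core have been measured in an ADME assay (Canis lupus familiaris, strain Beagle) for pharmacokinetics; on this read-out lower numbers stand for narrower distribution and higher numbers for wider distribution into tissues. Compound 1 gives 0.7 L/kg, the lowest of the three. Compound 2 gives 2.7 L/kg, and compound 3 gives 3.4 L/kg, the highest of the three numbers; the gap between compound 3 and compound 2 lies within the scatter, while the gap to compound 1 is beyond it.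

Among the measured compounds shown here, only one single-point step is available: a 3.9-fold higher number from compound 1 to compound 2 (0.59 log units; beyond the scatter). That step sits on a carbonyl carbon too, and shows that a small change at this position can move distribution modestly.

Compound 4 `CCn1c(-c2ccc(C(F)(F)F)nc2)nc2c(O[C@H]3CCN(C(=O)N4CC(OC)C4)C3)ncnc21` differs from compound 3 at the same kind of position: 3-methoxyazetidin-1-yl in place of 1,3-oxazol-4-yl on a carbonyl carbon. For the measured compounds named here, no measured pair shows this exact change, so the one step on a carbonyl carbon is the only guide, and it points to a modest shift at most.

In this assay the step of a 1.4-fold lower number from compound 3 to compound 4 (0.13 log units; within the scatter) is therefore expected to stay small, with a slight lean toward a lower number. Compound 4 is estimated at 2.5 L/kg, with a range from 1.2 L/kg to 5 L/kg.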

Compound 4, volume of distribution: 1.7 L/kg
Compound 4: the middle estimate sits 1.5-fold (0.17 log units) above what was measured, within the range that was stated.
By their numbers in this assay, from the lowest: compound 1; then compounds 4, 2 and 3 (each within the scatter of the next).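

In this assay, the step of a 2.0-fold lower number from compound 3 to compound 4 (0.30 log units; within the scatter) stays within the usual scatter, so this exchange on a carbonyl carbon does not separate the two compounds, even though a five-membered aromatic ring with 2 hetero atoms gives way to a four-membered non-aromatic ring bearing a methoxy group. Among the compounds shown here, the only earlier step on a carbonyl carbon, a 3.9-fold higher number from compound 1 to compound 2 (0.59 log units; beyond the scatter), lay beyond the scatter, so the two steps together show that a change on a carbonyl carbon can either leave a clear difference or none that can be told from the scatter, although these two pairs also differ in the rest of the molecule and in the groups exchanged. Nothing available explains why one step is clear and the other is not.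

Going by these compounds, it remains open whether the methoxy group matters, which azetidin-1-yl without it in place of 3-methoxyazetidin-1-yl on the same carbonyl carbon would test. An open-chain amine such as dimethylamino, or a group carrying a carboxylic acid, on that carbonyl carbon would show whether the read-out stays this close with a wider range of groups.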